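The source may report more compounds than this note shows. Statements on the series, on what has been measured and on what is new or still open speak of the compounds shown alone.

Two amides on the shared core, differing only at the carbonyl carbon that sits on the amide-type nitrogen, are measured so far. Compound 1 `CCCC(=O)N1CCC(NS(=O)(=O)c2ccc(NC(=O)CC3CCCC3)c3ccccc23)CC1` carries cyclopentylmethyl there and in an in vitro functional assay on CHO/Galpha16 cells for antagonist activity at C-C chemokine receptor type 8 (Homo sapiens), read by FLIPR (a lower number here means a stronger inhibitor, a higher number a weaker inhibitor), compound 1 gives 145 nM. Compound 2 `CCCC(=O)N1CCC(NS(=O)(=O)c2ccc(NC(=O)c3ccc(C)cc3)c3ccccc23)CC1` carries 4-methylphenyl and in this assay compound 2 gives 9.5 nM, the lowest of the two numbers, with a 15-fold lower number from compound 1 to compound 2 (1.18 log units; beyond the scatter).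

Compound 3 `CCCC(=O)N1CCC(NS(=O)(=O)c2ccc(NC(=O)C(CC)CC)c3ccccc23)CC1` is not yet measured; it differs from compound 2 by pentan-3-yl in place of 4-methylphenyl on a carbonyl carbon. For the measured compounds named here, the one measured step that bears on this is the swap between an open-chain group and an aromatic group on the same carbonyl carbon, a 15-fold lower number from compound 1 to compound 2 (1.18 log units; beyond the scatter), and compound 3 reverses that direction by moving back to an open-chain group. Compound 3 is therefore expected to give a clearly higher number, an 11-fold higher number from compound 2 to compound 3 (1.02 log units; beyond the scatter), landing nearer compound 1 than compound 2. The estimate for compound 3 is 100 nM, with a range of 30 nM to 400 nM.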

Compound 3, half-maximal inhibitory concentration: 639 nM
Compound 3: the middle estimate sits 6.4-fold (0.81 log units) below what was measured; the measured number lies above the stated range.
By their numbers in this assay, from the lowest: compound 2; then compound 1; then compound 3.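

With compound 3, the 4-methylphenyl group on this carbonyl carbon now stands well apart from both non-aromatic groups measured: a 67-fold higher number from compound 2 to compound 3 (1.83 log units; beyond the scatter). Those two non-aromatic groups also differ from each other, with a 4.4-fold higher number from compound 1 to compound 3 (0.64 log units; beyond the scatter), so pentan-3-yl, which has no ring, gives the highest number of the three and the position does not treat all non-aromatic groups alike. No measurement available here accounts for these differences.

From the compounds shown here alone, whether the aromatic ring alone carries the gain, or the methyl on it contributes, remains open, and plain phenyl or 4-chlorophenyl on the same carbonyl carbon would bear on that. Also open, going by these compounds, is whether a ring directly on the carbonyl carbon, such as cyclopentyl or cyclohexyl, behaves more like 4-methylphenyl or like pentan-3-yl.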